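Hydroxy in place of trifluoromethoxy on the shared core

The compounds below may be only part of what the source reports. "The series", "measured", "known", "first", "only" and "open" are said of these compounds alone.

In a functional assay on KB cells (Homo sapiens) for inhibition, read by sulforhodamine B assay (on this read-out higher numbers stand for weaker inhibition of growth and lower numbers for stronger inhibition of growth), compound 1 (`c1ccc(-c2ccc(-c3ccc(-c4nc5ccccc5[nH]4)cc3)cc2)cc1`) gives 39700 nM and compound 2 (`FC(F)(F)c1ccc(-c2ccc(-c3ccc(-c4nc5ccccc5[nH]4)cc3)cc2)cc1`) gives 47200 nM on the same core. Compound 3 (`FC(F)(F)Oc1ccc(-c2ccc(-c3ccc(-c4nc5ccccc5[nH]4)cc3)cc2)cc1`) gives 39100 nM and stands level with the other two, as all three values lie within the scatter of one another.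

Compound 4 (`Oc1ccc(-c2ccc(-c3ccc(-c4nc5ccccc5[nH]4)cc3)cc2)cc1`) carries hydroxy where compound 3 carries trifluoromethoxy: hydrogen in place of trifluoromethyl on an oxygen on an aromatic ring.

Among the compounds with values here, three measured steps bear on this change. Trifluoromethoxy in place of hydrogen on an aromatic carbon gave a 1.0-fold lower number from compound 1 to compound 3 (0.01 log units; within the scatter) and trifluoromethyl in place of hydrogen gave a 1.2-fold higher number from compound 1 to compound 2 (0.08 log units; within the scatter) on the same kind of carbon. Trifluoromethoxy in place of trifluoromethyl gave a 1.2-fold lower number from compound 2 to compound 3 (0.08 log units; within the scatter) as the third step. None of the three goes beyond the scatter. Within the data shown here, no measured compound carries a hydroxy group, however, so these steps are only a loose guide and the range has to stay wide.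

The expected step is a 1.3-fold lower number from compound 3 to compound 4 (0.12 log units; within the scatter) in this assay and so none beyond the scatter is foreseen. For compound 4 the estimated value is 30000 nM with an expected range from 10000 nM to 55000 nM in this estimate.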

Compound 4, concentration for 50% growth inhibition: 41000 nM
Compound 4: the middle estimate sits 1.4-fold (0.14 log units) below what was measured; the measured number falls inside the stated range.
By their numbers in this assay, from the lowest: compounds 3, 1, 4 and 2 (each within the scatter of the next).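

Hydroxy brings a hydrogen on the oxygen to this position for the first time, and in this assay the change from trifluoromethoxy leaves the read-out level (a 1.0-fold higher number from compound 3 to compound 4 (0.02 log units; within the scatter)). The same holds when hydroxy is read against the two other groups (a 1.2-fold lower number from compound 2 to compound 4 (0.06 log units; within the scatter); a 1.0-fold higher number from compound 1 to compound 4 (0.01 log units; within the scatter)). Hydrogen, trifluoromethyl, trifluoromethoxy and hydroxy at this place now all stand within the scatter of one another, so the flat picture seen in the earlier compounds extends to a group with no fluorine and to a free hydroxy, and no measurement at hand says why the values stay level.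

Still open, on these data alone, is whether any group on this aromatic carbon can move the number beyond the scatter, and an amine, a carboxylic acid or a longer chain such as butoxy would put that to the test. Also open is whether the same indifference holds once the rest of the shared core is changed, as all four compounds shown differ only at this one place.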